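The compounds below may be only part of what the source reports. "The series", "measured", "known", "first", "only" and "open" are said of these compounds alone.

Of the compounds shown here, three built on one shared core have been measured in an assay for inhibition of Fatty-acid amide hydrolase 1 (Rattus norvegicus); on this read-out lower numbers stand for stronger inhibition and higher numbers for weaker inhibition. Compound 1 `O=C(CCc1ccc(-c2ccccc2)cc1)c1ncc(-c2ccncc2)o1` gives 2.3 nM. Compound 2 `O=C(CCc1ccc(-c2ccccc2)cc1)c1ncc(-c2cccnc2)o1` gives 1.1 nM, and compound 3 `CS(=O)(=O)c1cnc(C(=O)CCc2ccc(-c3ccccc3)cc2)o1` gives 1.2 nM. Among these three numbers compound 3 holds the second highest place, yet it is not set apart from the others: the step of a 1.1-fold higher number from compound 2 to compound 3 (0.04 log units; within the scatter) and the step of a 1.9-fold lower number from compound 1 to compound 3 (0.28 log units; within the scatter) both lie within the scatter of repeated measurements, so the three compounds cannot be told apart with confidence.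

Compound 4 `NC(=O)c1ccc(-c2cnc(C(=O)CCc3ccc(-c4ccccc4)cc3)o2)nc1` is the next step from compound 3, in which (5-carbamoylpyridin-2-yl in place of methylsulfonyl on an aromatic carbon). Two of the measured steps bear on this change, because a 1.9-fold lower number from compound 1 to compound 3 (0.28 log units; within the scatter) and a 1.1-fold higher number from compound 2 to compound 3 (0.04 log units; within the scatter) each swapped the group at the same aromatic carbon of the five-membered aromatic ring with 1 nitrogen and 1 oxygen. Neither of them moved the number beyond the scatter. For compound 4 the expected step is therefore a 1.3-fold higher number from compound 3 to compound 4 (0.10 log units; within the scatter), again within the scatter and with no clear direction. Compound 4 is estimated at 1.5 nM, with a likely range from 0.4 nM to 6 nM.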

Compound 4, inhibition constant: 1.3 nM
Beside the measured number, compound 4's estimate is 1.2-fold (0.06 log units) above it; the range from low to high includes it.
By their numbers in this assay, from the lowest: compounds 2, 3, 4 and 1 (each within the scatter of the next, the first and the last beyond it).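

Putting 5-carbamoylpyridin-2-yl, with 9 heavy atoms and 1 hydrogen-bond donor, in place of methylsulfonyl, with 4 heavy atoms and no donor, on the aromatic carbon next to the ring oxygen gives a 1.1-fold higher number from compound 3 to compound 4 (0.03 log units; within the scatter) in this assay. The comparisons with the two plain pyridine compounds read the same way, with a 1.2-fold higher number from compound 2 to compound 4 (0.07 log units; within the scatter) and a 1.8-fold lower number from compound 1 to compound 4 (0.25 log units; within the scatter), so this position has now taken a pyridine ring carrying a carbamoyl group with no step beyond the scatter. Nothing available here gives a reason for this flat result.

Every group shown at this carbon is fairly large, so it stays open whether a bare hydrogen, a methyl group or a short amine would also stay within the scatter. A carboxylic acid in place of the carbamoyl group is likewise an open case.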